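Extending the sulfur-linked chain of compound 3 with a phenyl ring

The source may report more compounds than this note shows. Statements on the series, on what has been measured and on what is new or still open speak of the compounds shown alone.

Compound 3 `C=CCSc1nc2nc(C)cc(N3CC[C@@H](C)[C@@H](N(C)c4ncnc5[nH]ccc45)C3)n2n1` gives 32600 nM in a functional assay on MGC-803 cells (Homo sapiens) for inhibition, read by MTT assay, with a stated time of 72 h (on this read-out higher numbers stand for weaker inhibition and lower numbers for stronger inhibition), the highest of the three numbers measured; compound 1 `Cc1cc(N2CC[C@@H](C)[C@@H](N(C)c3ncnc4[nH]ccc34)C2)n2ncnc2n1` gives 4350 nM and compound 2 `Cc1cc(N2CC[C@@H](C)[C@@H](N(C)c3ncnc4[nH]ccc34)C2)n2nc(SCc3ccc(C(F)(F)F)cc3)nc2n1` gives 2680 nM. Compound 4 `Cc1cc(N2CC[C@@H](C)[C@@H](N(C)c3ncnc4[nH]ccc34)C2)n2nc(SCCCc3ccccc3)nc2n1` differs from compound 3 by phenethyl in place of vinyl on a saturated chain carbon bound to a sulfur. Going by the values given here, two measured steps bear on this change. The step of a 7.5-fold higher number from compound 1 to compound 3 (0.87 log units; beyond the scatter) shows that the allylsulfanyl group alone raises the number, while a 12-fold higher number from compound 2 to compound 3 (1.09 log units; beyond the scatter) shows that an aromatic ring at the end of the chain bound to the sulfur brings it back down, and a 1.6-fold lower number from compound 1 to compound 2 (0.21 log units; within the scatter) places the aryl-bearing analogue close to the unsubstituted parent. Among the compounds with values here, since compound 4 also carries an aromatic ring on that chain, a lower number than compound 3 is expected, of a size of a 7.2-fold lower number from compound 3 to compound 4 (0.86 log units; beyond the scatter), though the chain is longer than in compound 2 and that difference has no measured counterpart. Compound 4 is therefore expected to give about 4500 nM in this assay, within a range of 1500 nM to 14000 nM.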

Compound 4, half-maximal inhibitory concentration: > 100000 nM
Compound 4: no number, only a limit; the forecaster's own chance of this, stated with the estimate: 3%; middle value at least 22-fold (1.34 log units) away from the limit.
By their numbers in this assay, from the lowest: compounds 2 and 1 (each within the scatter of the next); then compound 3. At a limit, above all of these: compound 4.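

In this assay, compound 4 gives no number, only a limit of the assay: the limit of > 100000 nM in this assay, at which 1 of the 4 values shown sits. An aromatic ring on the chain bound to the sulfur therefore does not by itself keep the number down at this position, as phenethyl in place of 4-(trifluoromethyl)phenyl gives an at least 37-fold higher number from compound 2 to compound 4 (1.57 log units; beyond the scatter). The (3-phenylpropyl)sulfanyl group gives an at least 22-fold higher number from compound 1 to compound 4 (1.36 log units; beyond the scatter), and the change from allyl to 3-phenylpropyl gives an at least 3.0-fold higher number from compound 3 to compound 4 (0.48 log units; beyond the scatter), so two of the three sulfur-linked groups raise the number, with compound 2 going against that pattern.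

The limit leaves the true size of these steps open. The compounds shown also leave open whether the trifluoromethyl group or the shorter chain of compound 2 matters more, and how a plain benzylsulfanyl group or an amine at the end of the chain would read.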